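A few compounds are considered here, and "the series" means these few. Any claim that something is new, unique, unknown or untested is made for them only; others in the source may bear on it.

Going by the values given here, compound 1 `O=C(Nc1cc(Oc2ccc(Nc3nccc4[nH]cc(-c5ccc(F)cc5)c(=O)c34)cc2F)ccn1)C1CC1` holds the higher of the two numbers so far in an ADME assay on microsomes from liver (Homo sapiens) for metabolic stability (on this read-out lower numbers stand for a shorter-lived compound and higher numbers for a longer-lived compound), where compound 1 gives 13.2 h. Among the compounds with values here, compound 2 `Nc1nccc(Oc2ccc(Nc3nccc4[nH]cc(-c5ccc(F)cc5)c(=O)c34)cc2F)c1Cl` is the only other measured compound, and in this assay compound 2 gives 3.16 h; the change behind a 4.2-fold lower number from compound 1 to compound 2 (0.62 log units; beyond the scatter) sits on a different part of the molecule. Compound 3 `Cn1cc(-c2ccc(F)cc2)c(=O)c2c(Nc3ccc(Oc4ccnc(NC(=O)C5CC5)c4)c(F)c3)nccc21` differs from compound 1 by methyl in place of hydrogen on an aromatic nitrogen. No measured step touches this place, so nothing shown bears directly on it. For compound 3 the step is expected to stay within the scatter, a 1.3-fold lower number from compound 1 to compound 3 (0.12 log units; within the scatter). Compound 3 is therefore estimated at 10 h, with a range from 4 h to 25 h.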

Compound 3, half-life: 14.7 h
Estimate against measurement, compound 3: 1.5-fold (0.17 log units) below; low and high end bracket the measured number.
By their numbers in this assay, from the lowest: compound 2; then compounds 1 and 3 (each within the scatter of the next).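

Replacing hydrogen with methyl on the aromatic nitrogen gives a 1.1-fold higher number from compound 1 to compound 3 (0.05 log units; within the scatter) in this assay. This first measured step at this position shows that, for this one pair, the added methyl leaves the half-life within the scatter. Nothing available explains this result. As far as these compounds go, whether an ethyl, a longer chain or a chain ending in an amine would also stay within the scatter remains open. So does whether methyl at this position would behave the same way on compound 2 .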